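The compounds below may be only part of what the source reports. "The series", "measured", "known", "first", "only" and "open" are said of these compounds alone.

Compound 1 `CN1CCc2nc(C(=O)Nc3cc(C(=O)N(C)C)ccc3CNC(=O)c3ccc(Cl)s3)sc2C1`: > 900 ug/mL
Compound 2 `COC(=O)c1ccc(CNC(=O)c2ccc(Cl)s2)c(NC(=O)c2nc3c(s2)CN(C)CC3)c1`: 890 ug/mL

In a physicochemical assay for solubility, with a stated time of 12 h, at pH 1.2, tested at 10 mM (a higher number here means a more soluble compound, a lower number a less soluble compound), compound 1 gives > 900 ug/mL, which is a limit and not a number. Compound 3 `CN1CCc2nc(C(=O)Nc3cc(-c4nnn[nH]4)ccc3CNC(=O)c3ccc(Cl)s3)sc2C1` differs from it by 1H-tetrazol-5-yl in place of dimethylcarbamoyl on an aromatic carbon, with 1H-tetrazol-5-yl in place of dimethylcarbamoyl on an aromatic carbon. For the measured compounds named here, the only measured step, a number no higher from compound 1 to compound 2 (the limit leaves the size open), also alters the dimethylcarbamoyl group, though it leaves no ring in its place, and its size stays open at the limit of > 900 ug/mL in this assay, at which 1 of the 2 values shown sits. It gives weak guidance, pointing only to a modest fall or none, so the expected change is an at least 1.3-fold lower number from compound 1 to compound 3 (0.14 log units; that floor lies within the scatter). For compound 3 the estimated value is 650 ug/mL, with an expected range of 250 ug/mL to 1000 ug/mL.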

Compound 3, solubility: 320 ug/mL
Beside the measured number, compound 3's estimate is 2.0-fold (0.31 log units) above it; the range from low to high includes it.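

In this assay the group on this aromatic carbon, para to the (((5-chlorothiophen-2-yl)carbonyl)amino)methyl group, can move the number beyond the scatter, which the earlier step could not show. Placing 1H-tetrazol-5-yl there gives an at least 2.8-fold lower number from compound 1 to compound 3 (0.44 log units; beyond the scatter) and also a 2.8-fold lower number from compound 2 to compound 3 (0.44 log units; beyond the scatter) on the same carbon. The first of these steps has an open size, and the reason lies with compound 1: the limit of > 900 ug/mL in this assay, at which 1 of the 3 values shown sits.

The compounds shown leave open how a carboxylic acid or a primary amide on this carbon would compare with 1H-tetrazol-5-yl. They also leave open whether the fall follows the ring itself or the hydrogen-bond donor it brings.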